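Replacing 1-bromoethyl with azidomethyl on a carbonyl carbon

The source may report more compounds than this note shows. Statements on the series, on what has been measured and on what is new or still open speak of the compounds shown alone.

Compound 1 `COc1ccc(CN(C(=O)C(C)Br)c2cc(OC)c(OC)c(OC)c2)cc1O`: 160 nM
Compound 2 `C/C=C/C(=O)N(Cc1ccc(OC)c(N)c1)c1cc(OC)c(OC)c(OC)c1`: 310 nM
Compound 3 `C/C=C/C(=O)N(Cc1ccc(OC)c(C)c1)c1cc(OC)c(OC)c(OC)c1`: 32900 nM

All three values come from a functional assay on KYSE-450 cells (Homo sapiens) for inhibition, read by MTT assay, with a stated time of 48 h; a higher number here means a weaker inhibitor, a lower number a stronger inhibitor. Compound 1 has the lowest number of the three, but its value lies within the scatter of that of compound 2, while compound 3 stands far higher. The next compound, compound 4 `COc1ccc(CN(C(=O)CN=[N+]=[N-])c2cc(OC)c(OC)c(OC)c2)cc1O`, keeps the core of compound 1 and carries azidomethyl in place of 1-bromoethyl on a carbonyl carbon. Within the data shown here, no measured step covers a change at this place. The only one, a 110-fold higher number from compound 2 to compound 3 (2.03 log units; beyond the scatter), is methyl in place of amino on an aromatic carbon, so it gives no direct size for this change. It shows only that a single replacement in this small set can shift the number well beyond the scatter. A moderate rise in this assay is therefore expected, though with wide uncertainty. The estimate amounts to an expected 7.5-fold higher number from compound 1 to compound 4 (0.88 log units; beyond the scatter). Compound 4 is expected at about 1200 nM, with an estimated range of 200 nM to 9000 nM.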

Compound 4, half-maximal inhibitory concentration: 160 nM
For compound 4 the middle estimate is 7.5-fold (0.88 log units) above the measured one; the measured number lies below the stated range.
By their numbers in this assay, from the lowest: compounds 1, 4 and 2 (each within the scatter of the next); then compound 3.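

In this assay, azidomethyl in place of 1-bromoethyl on a carbonyl carbon gives no change at the digits printed from compound 1 to compound 4 (within the scatter), so on the core of compound 1 this assay does not separate the two groups. This position, on a carbonyl carbon whose other neighbours are an amide-type nitrogen, therefore accepts a change of atoms, with carbon and bromine leaving and carbon and nitrogen entering, and the number stays within the scatter. Among these compounds, that contrasts with the only earlier step, a 110-fold higher number from compound 2 to compound 3 (2.03 log units; beyond the scatter), which is a change at a different place. Nothing measured here offers an explanation for this result.

Going by these compounds, whether the position would hold its number with an amine, a carboxylic acid or a longer chain in place of azidomethyl remains open. The compounds shown also leave open whether the same replacement would give the same result on the core of compound 2.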